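The source may report more compounds than this note shows. Statements on the series, on what has been measured and on what is new or still open speak of the compounds shown alone.

Measured in a functional assay on HOS cells (Homo sapiens) for antiproliferative activity, read by sulforhodamine B assay; on this read-out higher numbers stand for weaker inhibition of growth and lower numbers for stronger inhibition of growth:
Compound 1 `CC[C@@H]1O[C@H](COCc2ccccc2)[C@@H](OCc2ccccc2)[C@H](OCc2ccccc2)[C@H]1OC(C)=O`: > 50000 nM (a limit)
Compound 2 `CCCCOC[C@H]1O[C@@H](CCC)[C@H](O)[C@@H](OCCCC)C1OCCCC`: > 50000 nM (a limit)
Compound 3 `CCCC[C@@H]1O[C@H](COCc2ccccc2)[C@@H](OCc2ccccc2)[C@H](OCc2ccccc2)[C@H]1O`: 40100 nM

The entries for compound 1 and compound 2 are limits of the assay, not numbers. Among the compounds with values here, compound 3 gives 40100 nM, the only true number of the three.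

Compound 4 `O[C@@H]1[C@@H](OCc2ccccc2)[C@H](OCc2ccccc2)[C@@H](COCc2ccccc2)O[C@H]1c1ccccc1` has phenyl in place of butyl on a saturated ring carbon, next to the ring oxygen: phenyl in place of butyl on a saturated ring carbon. Within the data shown here, no measured pair shows what this swap does, so no step beyond the usual scatter is expected in this assay. The expected change is a 1.1-fold lower number from compound 3 to compound 4 (0.06 log units; within the scatter). For compound 4, the estimated value is 35000 nM, with an expected range of 12000 nM to 60000 nM.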

Compound 4, concentration for 50% growth inhibition: > 50000 nM
Compound 4: no number, only a limit (the forecaster's own chance of this, stated with the estimate: 45%); at least 1.4-fold (0.15 log units) between middle value and limit.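

In this assay, within the data shown here, this is the first step that can be read at this ring carbon, next to the ring oxygen: phenyl in place of butyl gives an at least 1.2-fold higher number from compound 3 to compound 4 (0.09 log units; that floor lies within the scatter). Compound 4 gives > 50000 nM, which is a limit and not a number. So phenyl brings no visible gain here, but whether it causes a real loss stays unsettled due to the ceiling of the read-out: the limit of > 50000 nM in this assay, at which 3 of the 4 values shown sit. From the compounds shown here alone, whether an amine or a longer chain on this carbon would give a lower number remains open.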